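Aryl amide variation on the shared core

A few compounds are considered here, and "the series" means these few. Any claim that something is new, unique, unknown or untested is made for them only; others in the source may bear on it.

Values in an assay on MDA-MB-231 cells for binding affinity to C-X-C chemokine receptor type 4 (Homo sapiens), read by immunofluorescence and microscopy, with stated times of 10 min and 30 min; a lower number here means that less compound is needed, a higher number that more compound is needed for the effect:
compound 1 `Cc1ccc(S(=O)(=O)NCc2ccc(CNC(=O)c3ccc(Cl)cc3)cc2)cc1` gives 10 nM
compound 2 `O=C(NCc1ccc(CNS(=O)(=O)c2ccccc2)cc1)c1ccccc1Cl` gives 10 nM
compound 3 `O=C(NCc1ccc(CNS(=O)(=O)c2ccccc2)cc1)c1cccnc1` gives 10 nM

Compound 1 stands level with compounds 2 and 3 at the digits shown; no pair of the three separates beyond the scatter, so no order among them can be read. Among the measured compounds shown here, the single measured step that alters the group on the carbonyl carbon, no change at the digits printed from compound 2 to compound 3 (within the scatter), stayed within the scatter.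

The unmeasured compound 4 `Cc1ccc(S(=O)(=O)NCc2ccc(CNC(=O)c3cccc(C)c3)cc2)cc1` differs from compound 1 by 3-methylphenyl in place of 4-chlorophenyl on a carbonyl carbon. For the measured compounds named here, this is again a swap of the aromatic ring on the carbonyl carbon, the same kind of place as in the one measured step, which showed nothing beyond the scatter. The expected step of no change at the digits printed from compound 1 to compound 4 (within the scatter) is therefore none beyond the scatter. Compound 4 is estimated at 10 nM, with a range from 4 nM to 25 nM.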

Compound 4, effective concentration (reported as EC, without a stated level of effect): 1000 nM
Estimate against measurement, compound 4: 100-fold (2.00 log units) below; measured number above the stated range.
By their numbers in this assay, from the lowest: compounds 1, 2 and 3 (each within the scatter of the next); then compound 4.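

In this assay, the group on the carbonyl carbon is not indifferent to change: a 100-fold higher number from compound 1 to compound 4 (2.00 log units; beyond the scatter), whereas no change at the digits printed from compound 2 to compound 3 (within the scatter). The two groups exchanged in the new step match in the counts computed, each with a six-membered aromatic ring of carbon only and no hydrogen-bond donors or acceptors, so those counts do not separate them. Nothing measured here accounts for the step. On these data alone, whether it follows the gain of methyl or the loss of chlorine stays open. Plain phenyl on the carbonyl carbon of the core of compound 1, or a methoxy group in place of the methyl, would help to separate these.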